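A few compounds are considered here, and "the series" means these few. Any claim that something is new, unique, unknown or untested is made for them only; others in the source may bear on it.

Measured so far in a functional assay on SW-620 cells (Homo sapiens) for antiproliferative activity, read by MTT assay, with a stated time of 72 h; on this read-out higher numbers stand for weaker inhibition and lower numbers for stronger inhibition:
- compound 1, `O=C1O[C@H]([C@@H](O)Cn2cc(-c3cc(F)cc(F)c3)nn2)C(OCc2ccccc2)=C1OCc1ccccc1`: compound 1 gives > 100000 nM, a limit of the assay
- compound 2, `Cc1ccc(-c2cn(C/C=C3\OC(=O)C(OCc4ccccc4)=C3OCc3ccccc3)nn2)cc1`: compound 2 gives > 100000 nM, again a limit of the assay
- compound 3, `O=C1O[C@H]([C@@H](O)Cn2cc(CNS(=O)(=O)c3ccc(Cl)cc3F)nn2)C(OCc2ccccc2)=C1OCc1ccccc1`: compound 3 gives 42400 nM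

Compound 1 therefore sits at the upper limit of this assay, not at a measured number, and the same holds for compound 2, as summarised by the limit of > 100000 nM in this assay, at which 2 of the 3 values shown sit. Only compound 3, with its sulfonamide-bearing side chain, yields a number, and that number is itself weak. Compound 4, `COc1ccc(-c2cn(C[C@H](O)[C@H]3OC(=O)C(OCc4ccccc4)=C3OCc3ccccc3)nn2)cc1`, shares the core of compound 1 and differs from it in one place: 4-methoxyphenyl in place of 3,5-difluorophenyl on an aromatic carbon. Going by the values given here, no measured step exists between compounds that differ in a single place, so the direction of this change cannot be read from the data; compound 2, which also carries a simple aryl group on the same ring position, also sits at the limit. Compound 4 is accordingly expected to remain weak, at an estimated 90000 nM, within 30000 nM to 300000 nM. The expected step is an at least 1.1-fold lower number from compound 1 to compound 4 (0.04 log units; that floor lies within the scatter), which is estimated to be none beyond the scatter.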

Compound 4, half-maximal inhibitory concentration: 58200 nM
Compound 4: the middle estimate sits 1.5-fold (0.19 log units) above what was measured; the range from low to high includes it.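

In this assay, replacing 3,5-difluorophenyl with 4-methoxyphenyl on this aromatic carbon gives an at least 1.7-fold lower number from compound 1 to compound 4 (0.23 log units; that floor lies within the scatter), showing that a change at this position alone can bring the core of compound 1 to a measurable number. On these data alone, the value for compound 1 is a limit of the assay, so the true size of the step remains unknown, and its floor does not clear the usual scatter. The limit also remains common among the compounds shown: the limit of > 100000 nM in this assay, at which 2 of the 4 values shown sit.

As far as these compounds go, whether the shift comes from adding the methoxy group, removing the two fluorines or both remains open, as this single replacement changes them together. The compounds shown also leave open how an amine, a carboxylic acid or a longer chain at this aromatic carbon would read in this assay.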